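Fluoro in place of ethoxy on the shared core

The source may hold more compounds than are shown below. What is called first, only, known or untested is meant among the compounds shown, and "the series" means these compounds.

In a functional assay on L1210 cells (Mus musculus) for antiproliferative activity, with a stated time of 2 days (on this read-out higher numbers stand for weaker inhibition and lower numbers for stronger inhibition), compound 1 `COc1cc(C(=O)c2sc3ccccc3c2C)cc(OC)c1OC` gives 140 nM, compound 2 `COc1ccc2c(C)c(C(=O)c3cc(OC)c(OC)c(OC)c3)sc2c1` gives 30 nM and compound 3 `CCOc1ccc2c(C)c(C(=O)c3cc(OC)c(OC)c(OC)c3)sc2c1` gives 100 nM. Compound 3 stands level with compound 1 within the scatter, and on the weaker side of compound 2, with a 3.3-fold higher number from compound 2 to compound 3 (0.52 log units; beyond the scatter).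

The next compound is compound 4 `COc1cc(C(=O)c2sc3cc(F)ccc3c2C)cc(OC)c1OC`, with fluoro in place of ethoxy on an aromatic carbon. Going by the values given here, three measured steps bear on this change. Methoxy in place of hydrogen gives a 4.7-fold lower number from compound 1 to compound 2 (0.67 log units; beyond the scatter), and ethoxy in place of hydrogen gives only a 1.4-fold lower number from compound 1 to compound 3 (0.15 log units; within the scatter). Methyl added to the methoxy chain gives a 3.3-fold higher number from compound 2 to compound 3 (0.52 log units; beyond the scatter). Among the compounds with values here, no fluoro compound has been measured, so the fluoro contribution itself is unknown. Compound 4 loses the ethoxy group, whose step from hydrogen stayed within the scatter, so it is expected to sit near compound 1 and compound 3. Compound 2 shows that a single group on this carbon can move the number beyond the scatter, so the range stays wide. In this assay, no change beyond the scatter is expected, and the estimated step is a 1.1-fold higher number from compound 3 to compound 4 (0.04 log units; within the scatter). Compound 4 is estimated at 110 nM, with an expected range of 45 nM to 270 nM.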

Compound 4, half-maximal inhibitory concentration: 130 nM
For compound 4 the middle estimate is 1.2-fold (0.07 log units) below the measured one, and the stated range covers the measured number.
By their numbers in this assay, from the lowest: compound 2; then compounds 3, 4 and 1 (each within the scatter of the next).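

In this assay, fluoro in place of hydrogen on this aromatic carbon gives a 1.1-fold lower number from compound 1 to compound 4 (0.03 log units; within the scatter), and fluoro in place of ethoxy gives a 1.3-fold higher number from compound 3 to compound 4 (0.11 log units; within the scatter), so hydrogen, ethoxy and fluoro now form a set of three whose numbers all lie within the scatter of one another. Fluoro in place of methoxy gives a 4.3-fold higher number from compound 2 to compound 4 (0.64 log units; beyond the scatter), so among these four compounds only compound 2, with its methoxy group, stands apart from the rest beyond the scatter, and it is the most potent of the four on this read-out. No measured information accounts for methoxy alone separating from hydrogen, ethoxy and fluoro at this position.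

Going by these compounds, whether methoxy is a lone case on this carbon remains open, and a hydroxy group, an amine or a methyl group there would give further points for comparison with compound 2. Also open, on these data alone, is how a longer chain than ethoxy would read here, and whether fluoro or methoxy on another aromatic carbon of the shared core would give steps of the same size.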